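Swapping the aryl on the piperazine of a chalcone

The compounds below may be only part of what the source reports. "The series", "measured", "known", "first", "only" and "open" are said of these compounds alone.

Three compounds share a chalcone core carrying a piperazine whose second nitrogen bears a varied aryl group. Compound 1 `O=C(/C=C/c1ccccc1)c1ccc(N2CCN(c3ccccc3F)CC2)cc1` gives 0.57% in a functional assay on the whole organism (strain Kunming) for inhibition, with Mus musculus as the target, with a stated time of 1 h, at a dose of 40 mg/kg by the oral route; on this read-out lower numbers stand for less inhibition and higher numbers for more inhibition at the one dose given (going by the name of the read-out). Compound 2 `Cc1ccc(N2CCN(c3ccc(C(=O)/C=C/c4ccccc4)cc3)CC2)c(C)c1` gives 15%, and compound 3 `COc1cccc(N2CCN(c3ccc(C(=O)/C=C/c4ccccc4)cc3)CC2)c1` gives 16%, the highest of the three numbers, with compound 2 within the scatter of it and compound 1 well below it, as the steps of a number 14.4 percentage points higher from compound 1 to compound 2 (beyond the scatter) and a number 15.4 percentage points higher from compound 1 to compound 3 (beyond the scatter) show. Compound 4 `O=C(/C=C/c1ccccc1)c1ccc(N2CCN(c3ccccc3Cl)CC2)cc1` is the next compound, with the change (2-chlorophenyl in place of 3-methoxyphenyl on an amine nitrogen in a ring). Compound 4 carries a 2-chlorophenyl, and the only other 2-halophenyl measured is compound 1 with its 2-fluorophenyl, whose low number is the nearest guide. Compound 4 is therefore expected to give 5% (range 0% to 18%), a step of a number 11 percentage points lower from compound 3 to compound 4 (beyond the scatter) that is estimated to fall back toward compound 1 rather than stay at compound 3.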

Compound 4, a percentage reported as inhibition, in the whole organism at one dose (the size of the read-out at that dose, not a potency): 4.71%
Estimate against measurement, compound 4: 0.3 percentage points above; measured number inside the range.
By their numbers in this assay, from the lowest: compounds 1 and 4 (each within the scatter of the next); then compounds 2 and 3 (each within the scatter of the next).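

In this assay, chloro in place of fluoro on an aromatic carbon gives a number 4.1 percentage points higher from compound 1 to compound 4 (within the scatter), so the two 2-halophenyl compounds read alike. The 2-chlorophenyl also stands apart from the other two aryl groups, with a number 11.3 percentage points lower from compound 3 to compound 4 (beyond the scatter) and a number 10.3 percentage points lower from compound 2 to compound 4 (beyond the scatter). This separation holds only for the halogens, since compound 2, whose 2,4-dimethylphenyl also has a group at the 2 position, reads with compound 3.

No evidence is given that would account for this gap. As far as these compounds go, whether the halogen or its place on the ring matters remains open, and a 3-chlorophenyl or a 2-methoxyphenyl would bear on that.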